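This account rests on a few compounds, and the source may have more. Where it says the series, first, only, none or still open, it means among the compounds named here.

Compound 1 `CN(c1cc2ncc(=O)[nH]c2cc1NC(=S)NC(=O)c1ccccc1)C1CCCCC1` gives 11100 nM in an ADME assay on Huh-7 cells (Homo sapiens) for cytotoxicity; a lower number here means a stronger inhibitor, a higher number a weaker inhibitor.
Compound 2 `CN(c1cc2ncc(=O)[nH]c2cc1NC(=S)NC(=O)c1cccc(C(F)(F)F)c1)C1CCCCC1` gives 31500 nM in this assay.
Compound 3 `COc1cc(C(=O)NC(=S)Nc2cc3[nH]c(=O)cnc3cc2N(C)C2CCCCC2)cc(OC)c1OC` gives 15900 nM in this assay.

Among these three numbers compound 2 stands highest. Its nearest neighbour is compound 3, seen in a 2.0-fold lower number from compound 2 to compound 3 (0.30 log units; within the scatter), and its furthest is compound 1, seen in a 2.8-fold higher number from compound 1 to compound 2 (0.45 log units; beyond the scatter). The unmeasured compound 4 `CN(c1cc2ncc(=O)[nH]c2cc1NC(=S)NC(=O)c1cccc2ccccc12)C1CCCCC1` differs from compound 2 only at the aryl group on the carbonyl carbon: naphthalen-1-yl in place of 3-(trifluoromethyl)phenyl on a carbonyl carbon. For the measured compounds named here, two measured steps bear on this change, since both alter the same aryl group on the carbonyl carbon. One, a 2.8-fold higher number from compound 1 to compound 2 (0.45 log units; beyond the scatter), is modest; the other, a 2.0-fold lower number from compound 2 to compound 3 (0.30 log units; within the scatter), stays within the scatter, as does a 1.4-fold higher number from compound 1 to compound 3 (0.16 log units; within the scatter). Exchanging one aryl group for another at this carbonyl carbon has so far moved the number in this assay by no more than a modest amount, and a step of that size or smaller is expected here, with a slight lean downward given that compound 2 already holds the highest number. The expected step is therefore a 2.0-fold lower number from compound 2 to compound 4 (0.29 log units; within the scatter). Compound 4 is estimated to give 16000 nM in this assay, within a range from 6000 nM to 40000 nM.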

Compound 4, half-maximal inhibitory concentration: 9980 nM
Compound 4: the middle estimate sits 1.6-fold (0.20 log units) above what was measured; the range from low to high includes it.
By their numbers in this assay, from the lowest: compounds 4, 1, 3 and 2 (each within the scatter of the next, the first and the last beyond it).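

In this assay, the naphthalen-1-yl group puts a second six-membered aromatic ring of carbon only on the carbonyl carbon, and exchanging the 3-(trifluoromethyl)phenyl group for it gives a 3.2-fold lower number from compound 2 to compound 4 (0.50 log units; beyond the scatter). Measured against the other aryl groups, this second ring leaves no readable difference: the exchange for phenyl gives a 1.1-fold lower number from compound 1 to compound 4 (0.05 log units; within the scatter), and the exchange for 3,4,5-trimethoxyphenyl gives a 1.6-fold lower number from compound 3 to compound 4 (0.20 log units; within the scatter). Both steps beyond the scatter at this position now end or start at compound 2, so compound 2 stands apart from compounds 1 and 4, though compound 3 goes against a clean separation by lying within the scatter of compound 2, and no measurement at hand accounts for any of these numbers.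

On these data alone, the four compounds carry only aryl groups without nitrogen on this carbonyl carbon, so it remains open how the number would respond to a pyridin-3-yl ring, a phenyl ring bearing a carboxylic acid or an amine, or a saturated cyclohexyl ring there. All four also share the core and the methyl and cyclohexyl groups on its nitrogen, which leaves open whether the same small spread would hold with a shorter or longer chain in place of the cyclohexyl group.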